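A few compounds are considered here, and "the series" means these few. Any claim that something is new, unique, unknown or untested is made for them only; others in the source may bear on it.

Compound 1 `O=C(/C=C\Nc1ccc(F)cc1)c1cn(-c2ccccc2)nc1-c1ccc(F)cc1` gives 6500 nM in a functional assay on HT-29 cells (Homo sapiens) for antiproliferative activity, read by MTT assay, with a stated time of 48 h; on this read-out higher numbers stand for weaker inhibition and lower numbers for stronger inhibition.
Compound 3 `O=C(/C=C\Nc1ccc(O)cc1)c1cn(-c2ccccc2)nc1-c1ccc(F)cc1` gives 1900 nM in this assay.
Compound 2 `O=C(/C=C\Nc1ccc(C(F)(F)F)cc1)c1cn(-c2ccccc2)nc1-c1ccc(F)cc1` reaches only > 50000 nM in this assay, which is a limit of the assay and not a number.

Among these, compound 3 has the lowest number shown. Its nearest neighbour is compound 1, which sits one step higher: a 3.4-fold lower number from compound 1 to compound 3 (0.53 log units; beyond the scatter). Compound 2 sits at the limit (the limit of > 50000 nM in this assay, at which 1 of the 3 values shown sits), so its distance to compound 3 is known only as at least this much: an at least 26-fold lower number from compound 2 to compound 3 (1.42 log units; beyond the scatter). The remaining step, an at least 7.6-fold higher number from compound 1 to compound 2 (0.88 log units; beyond the scatter), also concerns only the same group.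

Compound 4 `O=C(/C=C\Nc1ccc(O)cc1)c1cn(-c2ccccc2)nc1-c1ccc(Cl)cc1` differs from compound 3 by chloro in place of fluoro on an aromatic carbon. All three measured steps swap a group at a different place from this one, so none of them speaks directly to the change from compound 3 to compound 4. Going by the values given here, with no measured step bearing on it, the expectation is a step that stays within the usual scatter, in no particular direction: no change at the digits printed from compound 3 to compound 4 (within the scatter) is what is estimated. Compound 4 is therefore expected to give about 1900 nM in this assay, with a range from 700 nM to 5500 nM.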

Compound 4, half-maximal inhibitory concentration: 2500 nM
Estimate against measurement, compound 4: 1.3-fold (0.12 log units) below, and the stated range covers the measured number.
By their numbers in this assay, from the lowest: compounds 3 and 4 (each within the scatter of the next); then compound 1. At a limit, above all of these: compound 2.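

Going by these compounds alone, every earlier step swapped a group at a different place, so the change from 4-fluorophenyl to 4-chlorophenyl is the first test of this position, and it gives a 1.3-fold higher number from compound 3 to compound 4 (0.12 log units; within the scatter) in this assay. With the hydroxy group kept, fluoro and chloro at this position cannot be told apart on this read-out, whereas a swap elsewhere, hydroxy in place of fluoro, gave a 3.4-fold lower number from compound 1 to compound 3 (0.53 log units; beyond the scatter) on the same read-out. Nothing measured here accounts for this result.

What the compounds shown leave open is whether a bromo, a methoxy, an amine or a carboxylic acid would fit at this position as well as these two halogens do. Chloro is also seen here only in a compound that carries the hydroxy group, so its effect alongside the other groups remains unknown.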